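The source may report more compounds than this note shows. Statements on the series, on what has been measured and on what is new or still open speak of the compounds shown alone.

Values in a functional assay on HeLa cells (Homo sapiens) for antiproliferative activity, read by CCK-8 assay, with a stated time of 48 h (on this read-out higher numbers stand for weaker inhibition and lower numbers for stronger inhibition), for the series

compound 1 `COc1ccc(/C=C\c2cc(OC)c(OC)c(OC)c2)cc1OCc1ccc(CN2CCCC[C@H]2C(=O)O)cc1` gives > 10000 nM
compound 2 `COc1ccc(/C=C\c2cc(OC)c(OC)c(OC)c2)cc1OCc1ccc(CN2CC[C@H](C(=O)O)C2)cc1` gives > 10000 nM
compound 3 `COc1ccc(/C=C\c2cc(OC)c(OC)c(OC)c2)cc1OCc1ccc(CN2CCCCC2C(=O)NCCN)cc1` gives 7300 nM

The entry for compound 1 (> 10000 nM) is a limit and not a number. The entry for compound 2 (> 10000 nM) is also a limit. Compound 3 (7300 nM) holds the only number shown.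

Compound 4 `COc1ccc(/C=C\c2cc(OC)c(OC)c(OC)c2)cc1OCc1ccc(CN[C@H](C(=O)O)[C@@H](C)O)cc1` has (1-carboxy-2-hydroxypropyl)amino in place of 2-((2-aminoethyl)carbamoyl)piperidin-1-yl on a saturated chain carbon bound to an aromatic carbon.

For the measured compounds named here, two measured steps bear on this (an at least 1.3-fold lower number from compound 1 to compound 3 (0.13 log units; that floor lies within the scatter) and an at least 1.3-fold lower number from compound 2 to compound 3 (0.13 log units; that floor lies within the scatter)) and both give only a floor. The step between the two limits (a step that the two limits leave unreadable from compound 1 to compound 2) adds no size. Compound 4 carries a carboxy group, as compound 1 and compound 2 do, and those two rest at the same limit (the limit of > 10000 nM in this assay, at which 2 of the 3 values shown sit). Going by the values given here, no measured compound carries the entering group, so the expectation is loose. A small move toward a higher number is expected in this assay (a 1.8-fold higher number from compound 3 to compound 4 (0.25 log units; within the scatter)) and a limit entry is likely. Compound 4 is estimated at 13000 nM (expected range 6000 nM to 30000 nM).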

Compound 4, half-maximal inhibitory concentration: > 10000 nM
Compound 4: only a limit was reported; the forecaster's own chance of this, stated with the estimate: 70%; the middle value lies beyond the limit too.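

In this assay, the open-chain (1-carboxy-2-hydroxypropyl)amino group places compound 4 with the two ring-bearing carboxy compounds, compound 1 and compound 2, at one limit: the limit of > 10000 nM in this assay, at which 3 of the 4 values shown sit.

Against compound 3, the change reads as an at least 1.3-fold higher number from compound 3 to compound 4 (0.13 log units; that floor lies within the scatter), so it gives only a floor and does not establish a real loss. The steps from compound 1 and compound 2 to compound 4 cannot be read, as both ends of each are limits; all three carboxy compounds, with or without a ring, remain unresolved, and only compound 3 carries a number.

On these data alone, it remains open whether the limit goes with the carboxy group itself or whether the number for compound 3 goes with its (2-aminoethyl)carbamoyl part. A methyl ester in place of the carboxylic acid, or a longer aminoalkyl chain on the amide, would help separate these readings.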